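Swapping the Amide Cap: What Compound 3 Should Show

The compounds below may be only part of what the source reports. "The series", "measured", "known", "first", "only" and "open" are said of these compounds alone.

Measured compounds:
compound 1 `CCN(CC)c1cc2[nH]c(C3CCCCC3)nc2cc1NC(=O)c1cnccn1` — > 100 ug/mL
compound 2 `CCN(CC)c1cc2[nH]c(C3CCCCC3)nc2cc1NC(=O)c1ccc(F)cc1` — > 100 ug/mL

In an ADME assay on Vero cells (Chlorocebus sabaeus) for cytotoxicity, read by resazurin assay, with a stated time of 3 days (on this read-out higher numbers stand for weaker inhibition and lower numbers for stronger inhibition), compound 1 gives > 100 ug/mL, which is a limit of the assay rather than a number. Compound 2 gives > 100 ug/mL in this assay, again only a limit. Both values sit at the limit of > 100 ug/mL in this assay, at which 2 of the 2 values shown sit, so the step that the two limits leave unreadable from compound 1 to compound 2 cannot be sized in either direction; compound 2 therefore stands only as a limit, with no measured number to place it.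

Compound 3 `CCCOCC(=O)Nc1cc2nc(C3CCCCC3)[nH]c2cc1N(CC)CC` differs from compound 2 by propoxymethyl in place of 4-fluorophenyl on a carbonyl carbon. No measured step is readable for this change, and the one step shown is itself unreadable, so nothing points to a shift beyond the scatter. Compound 3 is expected to give around 100 ug/mL, within a range of 40 ug/mL to 250 ug/mL, most likely again as a limit. The expected step of a number no higher from compound 2 to compound 3 (the limit leaves the size open) is none beyond the scatter.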

Compound 3, half-maximal inhibitory concentration: > 100 ug/mL
Compound 3 was reported as a limit; the forecaster's own chance of this, stated with the estimate: 75%; the middle value lies on the limit itself.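

In this assay compound 3 gives > 100 ug/mL as a limit of the assay and not a number. No step among compound 1, compound 2 and compound 3 can be read: the limit of > 100 ug/mL in this assay, at which 3 of the 3 values shown sit.

On these data alone, whether pyrazin-2-yl, 4-fluorophenyl and propoxymethyl on the carbonyl carbon differ at all in this assay stays open.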